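This account rests on a few compounds, and the source may have more. Where it says the series, first, only, none or still open, it means among the compounds named here.

Measured so far in an assay on Ltk cells with metabotropic glutamate receptor 5 (Homo sapiens) as the target, read by fluorescence and calcium flux; a lower number here means a stronger inhibitor, a higher number a weaker inhibitor:
- compound 1 `COc1cccnc1Nc1cccc(C)n1`: 458 nM
- compound 2 `CCCOc1cccnc1Nc1cccc(C)n1`: 1600 nM

Compound 2 gives the highest of the two numbers in this assay; its nearest neighbour is compound 1, and the step of a 3.5-fold higher number from compound 1 to compound 2 (0.54 log units; beyond the scatter) is the only one measured so far. The unmeasured compound 3 `Cc1cccc(Nc2ncccc2OCc2ccccc2)n1` differs from compound 2 by phenyl in place of ethyl on a saturated chain carbon bound to an oxygen on an aromatic ring. For the measured compounds named here, the one measured step bears on it only loosely: it shows that growing the group on the saturated chain carbon bound to the oxygen from hydrogen to ethyl raised the number by a modest amount, beyond the scatter. Whether a phenyl in that place carries the trend further is not shown by any measured pair, so the expectation for compound 3 is a small further rise, a 1.6-fold higher number from compound 2 to compound 3 (0.19 log units; within the scatter), with wide uncertainty in both directions. Compound 3 is thus estimated at 2500 nM, within a range of 600 nM to 10000 nM.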

Compound 3, half-maximal inhibitory concentration: 870 nM
Compound 3: middle estimate off by 2.9-fold (0.46 log units), on the high side; the measured number falls inside the stated range.
By their numbers in this assay, from the lowest: compounds 1, 3 and 2 (each within the scatter of the next, the first and the last beyond it).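

In this assay, phenyl in place of ethyl on the saturated chain carbon bound to the oxygen gives a 1.8-fold lower number from compound 2 to compound 3 (0.26 log units; within the scatter), so the growth of this group does not simply extend the earlier change, a 3.5-fold higher number from compound 1 to compound 2 (0.54 log units; beyond the scatter). Phenyl in place of hydrogen at the same carbon gives a 1.9-fold higher number from compound 1 to compound 3 (0.28 log units; within the scatter), so compound 3 cannot be told apart from either compound 1 or compound 2, although those two lie beyond the scatter of each other, and the size of the group alone does not order the three compounds. Nothing available speaks to what lies behind these numbers.

The compounds shown leave open how an amine or a longer chain ending in phenyl would read on this carbon. They also leave open whether substituents on the phenyl would separate compound 3 from compound 1.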